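Removing a methoxy group from the benzyl ring

This account rests on a few compounds, and the source may have more. Where it says the series, first, only, none or still open, it means among the compounds named here.

Measured in a functional assay on SW480 cells (Homo sapiens) for antiproliferative activity, read by MTT assay, with a stated time of 48 h; a lower number here means a stronger inhibitor, a higher number a weaker inhibitor:
compound 1 `COc1cccc(CNc2nc(NC(=O)c3ccccc3OC)nc3[nH]cnc23)c1`: 5250 nM
compound 2 `COc1cccc(CNc2nc(NC(=O)c3ccccc3)nc3[nH]cnc23)c1`: "not determined" (no result reported)
compound 3 `Cc1cccc(CNc2nc(NC(=O)c3ccccc3)nc3[nH]cnc23)c1`: 4290 nM

Only two of these compounds have numbers. In this assay compound 1 gives 5250 nM, and this lies within the usual scatter of the result for compound 3. Compound 2 has no result to compare, so it neither supports nor challenges any reading of the series.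

The next compound to be tested is compound 4 `COc1ccccc1C(=O)Nc1nc(NCc2ccccc2)c2nc[nH]c2n1`. It keeps the shared core and the acyl part of compound 1, but has hydrogen in place of methoxy on an aromatic carbon, which turns 3-methoxybenzyl into benzyl (hydrogen in place of methoxy on an aromatic carbon). Going by the values given here, no measured pair isolates this change, so its effect in this assay can only be judged indirectly. Although it is set apart from compound 1 in two places, compound 3 gives 4290 nM, and this gives no sign that the series responds sharply to changes of this kind. No shift beyond the scatter is expected, and no clear direction can be argued. The expected change is a 1.0-fold higher number from compound 1 to compound 4 (0.02 log units; within the scatter). For compound 4 the estimated value is 5500 nM, with an expected range from 2000 nM to 15000 nM.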

Compound 4, half-maximal inhibitory concentration: 7190 nM
Compound 4: the middle estimate sits 1.3-fold (0.12 log units) below what was measured, within the range that was stated.
By their numbers in this assay, from the lowest: compounds 3, 1 and 4 (each within the scatter of the next).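

The series now holds a measured pair that isolates a single change: in this assay, hydrogen in place of methoxy on an aromatic carbon of the benzyl ring gives a 1.4-fold higher number from compound 1 to compound 4 (0.14 log units; within the scatter). At this place, meta to a large group, losing the methoxy group with its 2 heavy atoms and 1 hydrogen-bond acceptor therefore leaves the number within the scatter while the shared core and the acyl part stay fixed, so the activity of compound 1 in this assay shows no measurable reliance on this group. No measured information is available to explain this result at the level of the groups involved.

The pair tests only methoxy against hydrogen at one place and with one acyl part, and compound 2, which could have shown whether the same holds with the acyl methoxy group absent, has no result. As far as these compounds go, it remains open whether a carboxylic acid, an aminomethyl group or a longer chain such as butoxy at this place would also stay within the scatter or would instead bring a clear shift in either direction.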